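A few compounds are considered here, and "the series" means these few. Any claim that something is new, unique, unknown or untested is made for them only; others in the source may bear on it.

Compound 1 `NS(=O)(=O)c1ccc(N2N=C(c3ccc(OCc4ccccc4)cc3)CC2c2ccc(F)cc2)cc1` at 90000 nM
Compound 2 `NS(=O)(=O)c1ccc(N2N=C(c3ccc(OCc4ccccc4)cc3)CC2c2ccc(Cl)cc2)cc1` at 82000 nM

Within the data shown here, in an ADME assay on Vero 76 cells (Chlorocebus sabaeus) for cytotoxicity, read by MTT assay, with a stated time of 96 h (on this read-out lower numbers stand for higher toxicity in this test and higher numbers for lower toxicity in this test), compound 1 gives 90000 nM as one of only two numbers so far, level with compound 2 at 82000 nM within the scatter. Compound 3 `NS(=O)(=O)c1ccc(N2N=C(c3ccc(Oc4ccccc4)cc3)CC2c2ccc(F)cc2)cc1` carries phenyl in place of benzyl on an oxygen on an aromatic ring. Among the measured compounds shown here, the only measured step (a 1.1-fold lower number from compound 1 to compound 2 (0.04 log units; within the scatter)) is chloro in place of fluoro on an aromatic carbon, a different change, so it offers only weak guidance. For the measured compounds named here, no measured step tests this swap, but nothing suggests a large shift, so the expected step (a 1.1-fold lower number from compound 1 to compound 3 (0.05 log units; within the scatter)) stays within the scatter. For compound 3 the estimate is 80000 nM with an expected range from 35000 nM to 110000 nM in this test.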

Compound 3, half-maximal cytotoxic concentration: 25000 nM
The estimate for compound 3 lay 3.2-fold (0.51 log units) above the measured number; measured number below the stated range.
By their numbers in this assay, from the lowest: compound 3; then compounds 2 and 1 (each within the scatter of the next).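

In this assay the change from benzyloxy to phenoxy gives a 3.6-fold lower number from compound 1 to compound 3 (0.56 log units; beyond the scatter) and so marks higher toxicity in this test, beyond the scatter. The earlier chloro for fluoro swap stayed within the scatter, so this is the first sign that the read-out responds to a change among the compounds shown. Nothing measured here accounts for the shift. The compounds shown leave open how the number responds to a longer chain on this oxygen, such as phenylethyl, or to a small group such as methyl. On these data alone, whether the same swap has a similar effect on the chloro compound also remains open.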